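Nitrile in Place of Trifluoromethyl on the Pendant Phenyl

The compounds below may be only part of what the source reports. "The series", "measured", "known", "first", "only" and "open" are said of these compounds alone.

Measured compounds:
compound 1, `Cc1nnc(-c2nc(C)c3c(c2N)C(=O)N(Cc2ccccc2)C3=O)o1`: < 5000 nM
compound 2, `Cc1noc(-c2nc(C)c3c(c2N)C(=O)N(Cc2ccc(Oc4ccc(F)cc4)cc2)C3=O)n1`: 23800 nM
compound 3, `Cc1noc(-c2nc(C)c3c(c2N)C(=O)N(Cc2cccc(C(F)(F)F)c2)C3=O)n1`: < 5000 nM

In a physicochemical assay for solubility, using the shake flask method, in simulated intestinal fluid, measured as kinetic solubility, with a stated time of 2 h, at 25 degrees C, at pH 6.5 (on this read-out lower numbers stand for lower solubility and higher numbers for higher solubility), compound 1 gives < 5000 nM, which is a limit of the assay rather than a number. Among the measured compounds shown here, compound 2 gives 23800 nM in this assay, the only plain number among the three. Compound 3 gives < 5000 nM in this assay, again a limit of the assay and not a number. Compound 3 therefore stands at the floor of what the assay reports, sharing that position with another compound: the limit of < 5000 nM in this assay, at which 2 of the 3 values shown sit. Where it would fall below that limit cannot be told from these data.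

Compound 4, `Cc1noc(-c2nc(C)c3c(c2N)C(=O)N(Cc2ccc(C#N)cc2)C3=O)n1`, has not yet been measured in this assay. It differs from compound 3 in one place: 4-cyanophenyl in place of 3-(trifluoromethyl)phenyl on a saturated chain carbon bound to an amide-type nitrogen in a ring. No step between two measured compounds is available here, so the size of such a change in this assay has not been shown by this set. The expected step is an at least 1.6-fold higher number from compound 3 to compound 4 (0.20 log units; that floor lies within the scatter), upward and possibly no larger than the usual scatter. Compound 4 is estimated to give about 8000 nM in this assay, with a range from 3000 nM to 30000 nM, and a substantial chance that the assay again reports only a limit.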

Compound 4, solubility: < 5000 nM
Compound 4 was reported as a limit; the forecaster's own chance of this, stated with the estimate: 35%; middle value at least 1.6-fold (0.20 log units) away from the limit.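

In this assay compound 4 is reported only as a limit, so 4-cyanophenyl on a saturated chain carbon bound to an amide-type nitrogen in a ring gives a read-out of the same kind as 3-(trifluoromethyl)phenyl in compound 3, and the floor of the assay now holds most of the set: the limit of < 5000 nM in this assay, at which 3 of the 4 values shown sit. The step between compound 3 and compound 4 cannot be read, as both values are limits, so this change has no measured size in either direction. Among the compounds shown here, the result does supply the first readable step of the set, an at least 4.7-fold lower number from compound 2 to compound 4 (0.67 log units; beyond the scatter), for cyano in place of 4-fluorophenoxy on an aromatic carbon, and this step is the only measure of a single change here.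

Going by these compounds, how far compound 3 and compound 4 each lie past the limit remains open, and so does whether the two groups differ at all in this assay. Also open, on these data alone, is where a carboxylic acid or a morpholine, in place of cyano on that aromatic carbon, would read in this assay, and whether either would give a plain number rather than a limit.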